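A Heteroaryl Swap Followed in Mouse Liver Microsomes

A few compounds are considered here, and "the series" means these few. Any claim that something is new, unique, unknown or untested is made for them only; others in the source may bear on it.

Three amides have been measured in an ADME assay on microsomes from liver (Mus musculus) for metabolic stability, read by LC-MS, with a stated time of 30 min, tested at 1 uM; on this read-out higher numbers stand for a more stable compound and lower numbers for a less stable compound. Compound 1 `O=C(NCc1ccc(S(=O)(=O)c2ccccc2)cc1)c1cc2ncccc2s1` gives 1.6%, the second highest of the three numbers. Compound 2 `O=C(NCc1ccc(S(=O)(=O)N2CCCCC2)cc1)c1ccn2cncc2c1` gives 1%, which lies within the scatter of compound 1. Compound 3 `O=C(NCc1ccc(S(=O)(=O)c2ccc(F)c(F)c2)cc1)c1cc2cnccc2[nH]1` gives 58%, a number beyond the scatter above compound 1. Compound 4 `O=C(NCc1ccc(S(=O)(=O)c2ccccc2)cc1)c1nc2cnccc2[nH]1` has not yet been tested in this assay. It differs from compound 1 in one place: a group of 9 heavy atoms (6 carbon, 3 nitrogen; one five-membered aromatic ring with 2 hetero atoms, one six-membered aromatic ring with 1 hetero atom) in place of a group of 9 heavy atoms (7 carbon, 1 nitrogen, 1 sulfur; one five-membered aromatic ring with 1 hetero atom, one six-membered aromatic ring with 1 hetero atom), on a carbonyl carbon. For the measured compounds named here, no measured pair isolates this change, so the step has to be judged from the whole set. Compound 4 is expected to be more stable than compound 1, with a modest step of a number 13.4 percentage points higher from compound 1 to compound 4 (beyond the scatter), since compound 3, whose group on the carbonyl also carries a hydrogen-bond donor, gives 58%. The estimate for compound 4 is 15%, with a range from 2% to 55%.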

Compound 4, percent of the compound remaining: 7.3%
Compound 4: middle estimate off by 7.7 percentage points, on the high side, within the range that was stated.
By their numbers in this assay, from the lowest: compounds 2, 1 and 4 (each within the scatter of the next); then compound 3.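

In this assay, the swap on the carbonyl carbon gives a number 5.7 percentage points higher from compound 1 to compound 4 (within the scatter). For the compounds shown here, this is the first direct reading at this position, and it shows that this exchange, which brings in a hydrogen-bond donor, does not on its own shift the number beyond the scatter. Nothing measured here offers an explanation for this outcome.

As far as these compounds go, compound 3 differs from compound 4 in more than one place, so what separates compound 3 from the others remains open. Also open, from the compounds shown here alone, is how a carboxylic acid or a morpholine on this carbonyl carbon would read.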